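Swapping a Methylsulfanyl Group for a Selenium-Bearing Benzyl

A few compounds are considered here, and "the series" means these few. Any claim that something is new, unique, unknown or untested is made for them only; others in the source may bear on it.

Measured so far:
- Compound 1, `CS/C(=N\C(=O)c1csc([N+](=O)[O-])c1)NC(=O)c1csc([N+](=O)[O-])c1`, gives 63400 nM in a functional assay on HepG2 cells (Homo sapiens) for cytotoxicity, read by MTT assay, with a stated time of 72 h; on this read-out higher numbers stand for weaker inhibition of growth and lower numbers for stronger inhibition of growth.
- Compound 2, `C[Se]/C(=N\C(=O)c1cc(-c2ccccc2)nc2ccccc12)NC(=O)c1cc(-c2ccccc2)nc2ccccc12`, gives 4540 nM in this assay.

Of these two numbers, compound 1 carries the higher one, so it is the weaker growth inhibitor of the pair; compound 2 sits well below it, and that gap lies beyond the usual scatter. Within the data shown here, no step is traced between them, since they differ in more than one place, so their two values are all that can be said.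

Compound 3, `O=C(/N=C(/NC(=O)c1csc([N+](=O)[O-])c1)[Se]Cc1ccccc1)c1csc([N+](=O)[O-])c1`, keeps the core of compound 1 and changes one spot: a group of 8 heavy atoms (7 carbon, 1 selenium; one six-membered aromatic ring of carbon only) in place of a group of 2 heavy atoms (1 carbon, 1 sulfur; no ring), on a carbon with a double bond to nitrogen. Compound 2 shows that a selenium-bearing compound can reach a low number, but it also carries entirely different carbonyl partners, so it offers no clean guide. For compound 3 a modest fall in the number, a step toward stronger growth inhibition that may only just clear the scatter, is expected, giving an estimate of 25000 nM with a range from 6000 nM to 80000 nM, which means an expected step of a 2.5-fold lower number from compound 1 to compound 3 (0.40 log units; beyond the scatter).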

Compound 3, concentration for 50% growth inhibition: 34100 nM
Estimate against measurement, compound 3: 1.4-fold (0.13 log units) below, within the range that was stated.
By their numbers in this assay, from the lowest: compound 2; then compounds 3 and 1 (each within the scatter of the next).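

In this assay the exchange of the methylsulfanyl group for the selenium-bearing benzyl group gives a 1.9-fold lower number from compound 1 to compound 3 (0.27 log units; within the scatter) and stays within the scatter, so the two compounds cannot be told apart on this read-out. Among these compounds, this is the first view of this position on its own: on a carbon with a double bond to nitrogen, a group of 8 heavy atoms with an aromatic ring can replace a group of 2 heavy atoms and no ring, with no readable shift in growth inhibition. Nothing measured here explains this outcome, and no outside data bear on it.

This single step changes sulfur to selenium and methyl to benzyl at once, so it cannot show what each change does alone; a benzylsulfanyl group or a methylselanyl group on the core of compound 1 would separate the two. Going by these compounds, how far this position stays insensitive is also open, as a longer alkyl chain or an amine in the same place would test a different kind of group.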